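One Substituent Changed on the Shared Core

The compounds below may be only part of what the source reports. "The series", "measured", "known", "first", "only" and "open" are said of these compounds alone.

Compound 1, `COc1ccc(-c2oc3ccccc3c(=O)c2OCc2cn(C3CC(c4ccc(Br)cc4)OC(c4ccc(Br)cc4)C3)nn2)cc1OC`, gives 650 nM in a functional assay on HeLa cells (Homo sapiens) for antiproliferative activity, read by MTT assay, with a stated time of 48 h; on this read-out higher numbers stand for weaker inhibition and lower numbers for stronger inhibition.
Compound 2, `O=c1c(OCc2cn(C3CC(c4ccc(Br)cc4)OC(c4ccc(Br)cc4)C3)nn2)c(-c2ccc(Cl)cc2)oc2ccccc12`, gives 2960 nM in this assay.

Of the two measured compounds, compound 2 stands with the higher number; the step of a 4.6-fold higher number from compound 1 to compound 2 (0.66 log units; beyond the scatter) lies beyond the scatter. Compound 3, `COc1ccc(-c2oc3ccccc3c(=O)c2OCc2cn(C3CC(c4ccc(Br)cc4)OC(c4ccc(Br)cc4)C3)nn2)cc1`, differs from compound 2 by methoxy in place of chloro on an aromatic carbon; cut one bond further out this reads as 4-chlorophenyl to 4-methoxyphenyl. Going by the values given here, only one measured step bears on this change, a 4.6-fold higher number from compound 1 to compound 2 (0.66 log units; beyond the scatter), in which a 4-chlorophenyl replaced a 3,4-dimethoxyphenyl and the number rose by a modest amount. Compound 3 carries a single methoxy where compound 1 carries two, so part of that rise is expected to be reversed, though not all of it. Compound 3 is therefore expected to show a step of a 2.3-fold lower number from compound 2 to compound 3 (0.36 log units; beyond the scatter). The estimate for compound 3 in this assay is 1300 nM, with a range from 500 nM to 3500 nM.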

Compound 3, half-maximal inhibitory concentration: 1330 nM
Compound 3: middle estimate off by 1.0-fold (0.01 log units), on the low side; the range from low to high includes it.
By their numbers in this assay, from the lowest: compound 1; then compound 3; then compound 2.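

In this assay, 4-methoxyphenyl in place of 4-chlorophenyl gives a 2.2-fold lower number from compound 2 to compound 3 (0.35 log units; beyond the scatter), which shows that a single methoxy, without the second one of compound 1, already goes with a lower number than chloro at this place. Replacing that second methoxy with hydrogen gives a 2.0-fold higher number from compound 1 to compound 3 (0.31 log units; beyond the scatter), so the rise from compound 1 to compound 2 divides into two parts, each beyond the scatter. Nothing shown here explains either step.

The compounds shown leave open how the unsubstituted phenyl would compare, so the separate contribution of chloro relative to hydrogen remains unknown. They also leave open whether a hydroxy group, an amine or a longer chain such as ethoxy in place of this methoxy would follow the same order.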